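The source may hold more compounds than are shown below. What is called first, only, known or untested is meant among the compounds shown, and "the series" means these compounds.

In a physicochemical assay for lipophilicity, read by HPLC, at pH 7.5 (on this read-out higher numbers stand for higher lipophilicity and lower numbers for lower lipophilicity), compound 1 (`CCOc1ccccc1-c1ccc(-c2nc3cnccc3cc2C#N)cc1`) gives 3.8, compound 2 (`CCOc1ccccc1-c1ccc(-c2nc3cnccc3c(N[C@H](CC)C(=O)N(C)C)c2C#N)cc1`) gives 3.7 and compound 3 (`CCOc1ccccc1-c1ccc(-c2nc3cnccc3c(N[C@H](CC)C(=O)O)c2C#N)cc1`) gives 2.1, the lowest of the three numbers. Compound 4 (`CCOc1ccccc1-c1ccc(-c2nc3cnccc3c(NC(C(N)=O)C3CC3)c2C#N)cc1`) is not yet measured. Its structural difference from compound 3 is a group of 7 heavy atoms (5 carbon, 1 nitrogen, 1 oxygen; one three-membered non-aromatic ring of carbon only) in place of a group of 6 heavy atoms (4 carbon, 2 oxygen; no ring), on a nitrogen on an aromatic ring, so the 1-carboxypropyl group leaves. For the measured compounds named here, two measured steps bear directly on that group: a number 1.70 log units lower from compound 1 to compound 3 (beyond the scatter) and a number 1.60 log units lower from compound 2 to compound 3 (beyond the scatter). Both are large. By contrast, a number 0.10 log units lower from compound 1 to compound 2 (within the scatter) brings in (1-(dimethylcarbamoyl)propyl)amino and stays within the scatter. Going by the values given here, no measured compound carries the entering group or its three-membered ring, so the size of the step rests on these comparisons alone. A large rise beyond the scatter is expected, somewhat smaller than the two large steps, and the expected step is a number 1.30 log units higher from compound 3 to compound 4 (beyond the scatter). Compound 4 is estimated at 3.4, with an expected range from 2.9 to 3.9.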

Compound 4, distribution coefficient: 3
For compound 4 the middle estimate is 0.40 log units above the measured one; the range from low to high includes it.
By their numbers in this assay, from the lowest: compound 3; then compound 4; then compounds 2 and 1 (each within the scatter of the next).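

For the compounds shown here, on the nitrogen on an aromatic ring, the earlier compounds left the dimethylcarbamoyl side chain and the carboxylic acid as the two cases, one close to the unsubstituted compound and one far from it; in this assay the entering group falls between them, with a number 0.90 log units higher from compound 3 to compound 4 (beyond the scatter) on one side and a number 0.70 log units lower from compound 2 to compound 4 (beyond the scatter) on the other. Substitution on the aromatic carbon therefore need not leave the number unchanged when the side chain lacks the acid, as a number 0.80 log units lower from compound 1 to compound 4 (beyond the scatter) shows, unlike the step from compound 1 to compound 2. No measurement among these compounds accounts for the size of these steps.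

Compound 4 differs from compound 2 in both the amide and the three-membered ring, so their shares remain unseparated. Going by these compounds, a 1-carbamoylpropyl group would divide the two, and an amine or a longer chain at this nitrogen remains open too.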